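Removing the lactam benzyl group in the ataxin-2 series

A few compounds are considered here, and "the series" means these few. Any claim that something is new, unique, unknown or untested is made for them only; others in the source may bear on it.

Compound 1 `O=C(O)c1ccc(COc2ccc(CNC(=O)[C@@H]3CCC(=O)N3Cc3ccccc3)cc2)cc1` carries a benzyl group on the ring amide nitrogen of the shared core; in an assay on HEK293 cells for inhibition of Ataxin-2 (Mus musculus), read by fluorescence and Amplex Red (on this read-out higher numbers stand for weaker inhibition and lower numbers for stronger inhibition), compound 1 gives 4500 nM. Compound 2 `O=C(O)c1ccc(COc2ccc(CNC(=O)[C@@H]3CCC(=O)N3Cc3ccc(C(F)(F)F)cc3)cc2)cc1` adds a trifluoromethyl on an aromatic carbon of that benzyl. In this assay compound 2 gives only a limit, > 5000 nM. Within the data shown here, the single measured step, an at least 1.1-fold higher number from compound 1 to compound 2 (0.04 log units; that floor lies within the scatter), therefore ends at the floor described by the limit of > 5000 nM in this assay, at which 1 of the 2 values shown sits, and shows no change beyond the scatter. Compound 3 `O=C1CC[C@@H](C(=O)NCc2ccc(OCc3ccc(C(=O)O)cc3)cc2)N1` is the next point: hydrogen in place of 4-(trifluoromethyl)benzyl on an amide-type nitrogen in a ring. Among the measured compounds shown here, no measured step removes the whole benzyl group, so the bearing of the existing data is indirect: an at least 1.1-fold higher number from compound 1 to compound 2 (0.04 log units; that floor lies within the scatter) shows that a change on the benzyl aromatic ring left the number at the floor described by the limit of > 5000 nM in this assay, at which 1 of the 2 values shown sits. Compound 1, with 4500 nM in this assay, is itself only a weak inhibitor on this read-out. A step in this assay of uncertain direction is expected, most probably ending again at a limit; the expected step is a step that the limit leaves unreadable from compound 2 to compound 3. Compound 3 is estimated at 8000 nM, in the range 2500 nM to 25000 nM.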

Compound 3, half-maximal inhibitory concentration: > 5000 nM
Compound 3 was reported as a limit; the forecaster's own chance of this, stated with the estimate: 60%; the middle value does not contradict the limit.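

Hydrogen in place of benzyl on the amide-type nitrogen gives an at least 1.1-fold higher number from compound 1 to compound 3 (0.04 log units; that floor lies within the scatter), so in this assay removing the whole benzyl group shows no change beyond the scatter, and the true size of the step remains unknown past that floor. Compound 2 and compound 3 are both limits, so the step between them cannot be read and the 4-(trifluoromethyl)benzyl group cannot be ranked against hydrogen. The new information is that a compound with no aromatic ring on this nitrogen, compound 3, also gives only a limit, so neither change to the benzyl group has produced a readable number: the limit of > 5000 nM in this assay, at which 2 of the 3 values shown sit.

What the compounds shown leave open is whether any group on this nitrogen can bring the number clearly under that of compound 1, 4500 nM, and how much weaker compound 2 and compound 3 truly are. A longer chain such as phenethyl, a small methyl group on the same nitrogen, or an amine on the benzyl aromatic ring would inform this position only if its value came out as a number rather than a limit.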